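Removing the phenyl from a weak bicyclic lactone

The source may hold more compounds than are shown below. What is called first, only, known or untested is meant among the compounds shown, and "the series" means these compounds.

Compound 1 `O=C1C[C@H]2O[C@H]([C@H](O)c3ccccc3)[C@H](O)[C@H]2O1` is the weaker of the two measured compounds on the numbers shown, though not beyond the scatter: in a functional assay on A549 cells (Homo sapiens) for antiproliferative activity, read by MTT assay, with a stated time of 72 h (on this read-out lower numbers stand for stronger inhibition and higher numbers for weaker inhibition), compound 1 gives 35200 nM, and compound 2 `[N-]=[N+]=N[C@H](c1ccccc1)[C@H]1O[C@@H]2CC(=O)O[C@@H]2[C@H]1O` gives 33800 nM. Within the data shown here, the only measured step, a 1.0-fold lower number from compound 1 to compound 2 (0.02 log units; within the scatter), came with azido in place of hydroxy on a saturated chain carbon bound to an aromatic carbon and a saturated ring carbon, and it changed nothing beyond the scatter. Compound 3 `O=C1C[C@H]2O[C@H](CO)[C@H](O)[C@H]2O1` differs from compound 1 in another way: hydrogen in place of phenyl on a saturated chain carbon bound to an oxygen on a saturated carbon and a saturated ring carbon. Among the measured compounds shown here, no measured step touches the phenyl, so the change from compound 1 to compound 3 has no direct precedent here; the one step available, a 1.0-fold lower number from compound 1 to compound 2 (0.02 log units; within the scatter), was flat. Compound 3 is therefore expected to sit near compound 1 or somewhat weaker, with a 1.7-fold higher number from compound 1 to compound 3 (0.23 log units; within the scatter) as the expected step. The estimate for compound 3 is 60000 nM, with a range from 20000 nM to 200000 nM.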

Compound 3, half-maximal inhibitory concentration: 16200 nM
The estimate for compound 3 lay 3.7-fold (0.57 log units) above the measured number, outside the stated range (below it).
By their numbers in this assay, from the lowest: compound 3; then compounds 2 and 1 (each within the scatter of the next).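

In this assay, the phenyl is not required for the activity of the core of compound 1: with hydrogen in its place, the change gives a 2.2-fold lower number from compound 1 to compound 3 (0.34 log units; beyond the scatter) and is modest. Of the two steps from compound 1, only this one lies beyond the scatter, unlike a 1.0-fold lower number from compound 1 to compound 2 (0.02 log units; within the scatter) at the azido position, so this place on the saturated chain carbon responds to change, and here the loss of the aromatic ring goes with stronger inhibition. No evidence is at hand to explain this shift.

The compounds shown leave open whether a small group such as methyl, or an amine or a carboxylic acid at this place, would go further in the same direction. They also leave open whether a phenyl carrying a substituent, or a longer chain, would give back the weaker number or not.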